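The source may report more compounds than this note shows. Statements on the series, on what has been measured and on what is new or still open speak of the compounds shown alone.

Of the compounds shown here, three carry numbers so far. In a functional assay (blood) for inhibition, with Homo sapiens as the target (on this read-out higher numbers stand for weaker inhibition and lower numbers for stronger inhibition), compound 1 `CC(=O)/C(=N\O)c1ccc(Sc2cc(F)cc(C3CCOCC3)c2)cc1` gives 850 nM. Compound 2 `C/C(=N\O)c1cccc(Sc2cc(F)cc(C3CCOCC3)c2)c1` gives 2910 nM in this assay, a higher number that lies beyond the scatter. Compound 3 `COC1(c2cc(F)cc(Sc3ccc4c(c3)CC/C4=N\OCC#N)c2)CCOCC1` gives 30 nM in this assay, a lower number that also lies beyond the scatter. On these three numbers compound 1 therefore stands second highest, nearest to compound 2 and furthest from compound 3.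

Compound 4 `CN(C)/C(=N\O)c1ccc(Sc2cc(F)cc(C3CCOCC3)c2)cc1` has not yet been measured. It differs from compound 1 in one place: dimethylamino in place of acetyl on a carbon with a double bond to nitrogen. For the measured compounds named here, compound 2 and compound 3 each differ from compound 1 in more than one place, so no measured step covers this change on its own; what compound 2 and compound 3 show is only that variation at the carbon with a double bond to nitrogen, together with other changes, has given numbers both higher and lower than that of compound 1.

Going by the values given here, with no measured step for this exchange, the step of a 1.8-fold higher number from compound 1 to compound 4 (0.25 log units; within the scatter) is expected to be modest, toward a somewhat higher number if any, and possibly none beyond the scatter. Compound 4 is thus expected to give about 1500 nM in this assay, within a range from 400 nM to 6000 nM.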

Compound 4, half-maximal inhibitory concentration in the Homo sapiens assay: 280 nM
Estimate against measurement, compound 4: 5.4-fold (0.73 log units) above; measured number below the stated range.
By their numbers in the Homo sapiens assay, from the lowest: compound 3; then compound 4; then compound 1; then compound 2.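

For the compounds shown here, this is the first step that isolates the carbon with a double bond to nitrogen, with the rest of the core of compound 1 unchanged: in the Homo sapiens assay, dimethylamino in place of acetyl gives a 3.0-fold lower number from compound 1 to compound 4 (0.48 log units; beyond the scatter). The earlier compounds shown here showed variation at this place only together with other changes, whereas this step shows that the exchange alone moves the number for inhibition beyond the scatter. In a physicochemical assay for acid dissociation, compound 1 gives 8.4 and compound 4 gives 14.1. In the physicochemical assay, the same exchange gives a number 5.70 log units higher from compound 1 to compound 4 (beyond the scatter), so the lower number for inhibition of compound 4 comes with a proton that is given up far less readily, a link that this single pair can show but cannot establish as cause: the measured acid dissociation constant of compound 1, 8.4, and of compound 4, 14.1, a number 5.70 log units higher (beyond the scatter)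

Going by these compounds, whether the lower number for inhibition follows the shift in acid dissociation or belongs to dimethylamino itself stays open, since both changes rest on the same pair. A primary amine or a methoxy group on the same carbon, with the rest of the core of compound 1 kept, would help to separate the two readings.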